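Lengthening the acid chain through an ether oxygen

The source may report more compounds than this note shows. Statements on the series, on what has been measured and on what is new or still open speak of the compounds shown alone.

Measured so far:
compound 1, `Cc1nc(-c2ccc(C(F)(F)F)cc2)sc1CNc1ccc(CCC(=O)O)cc1`: 108%
compound 2, `Cc1nc(-c2ccc(C(F)(F)F)cc2)sc1CNc1ccc(CC(=O)O)cc1`: 18%
compound 3, `O=C(O)/C=C/c1ccc(NCc2cccc(Oc3ccccc3)c2)cc1`: 76%

In a functional assay on CHO cells for agonist activity at Free fatty acid receptor 1 (Homo sapiens), read by a luciferase reporter (on this read-out lower numbers stand for smaller maximal responses and higher numbers for larger maximal responses), compound 2 gives 18%, the lowest of the three numbers; compound 3 gives 76%, a higher number, and compound 1 lies furthest away, a number 90 percentage points lower from compound 1 to compound 2 (beyond the scatter) on going from the longer to the shorter acid. Compound 4, `Cc1nc(-c2ccc(C(F)(F)F)cc2)sc1CNc1ccc(OCC(=O)O)cc1`, has not yet been measured in this assay. It differs from compound 2 in one place: carboxymethoxy in place of carboxymethyl on an aromatic carbon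

Among the measured compounds shown here, the only step that bears on this change is the one from compound 1 to compound 2, a large loss when the chain between the ring and the acid was cut by one atom. Compound 4 restores the length of that chain, though with an oxygen in place of a carbon. A large step upward is therefore expected, a number 47 percentage points higher from compound 2 to compound 4 (beyond the scatter), but not necessarily the full return to the level of compound 1. Compound 4 is estimated at 65%, within a range from 30% to 100%.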

Compound 4, largest response reached (reported as percent of maximum), in percent of the reference or control that the assay uses: 100%
Estimate against measurement, compound 4: 35 percentage points below, within the range that was stated.
By their numbers in this assay, from the lowest: compound 2; then compound 3; then compounds 4 and 1 (each within the scatter of the next).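

In this assay, carboxymethoxy in place of carboxymethyl on this aromatic carbon, para to a large group, brings a large gain (a number 82 percentage points higher from compound 2 to compound 4 (beyond the scatter)). Set against the 2-carboxyethyl group, carboxymethoxy leaves a difference that cannot be told from the usual scatter (a number 8 percentage points lower from compound 1 to compound 4 (within the scatter)), so at this position an ether oxygen in the chain is compatible with a maximal response on the level of the all-carbon acid. Among these three acids on the shared core, only the carboxymethyl compound falls away, which shows that the earlier loss was not tied to the absence of an oxygen or to any need for an all-carbon chain.

Going by these compounds, whether a longer chain, a sulfur atom in place of the ether oxygen, or an amine linking the acid to the ring would hold this response remains open. Nothing at hand accounts for the recovery seen with the ether oxygen.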